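A few compounds are considered here, and "the series" means these few. Any claim that something is new, unique, unknown or untested is made for them only; others in the source may bear on it.

Working notes on the series, read in an ADME assay on microsomes from liver (Homo sapiens) for metabolic stability, read by LC-MS, tested at 1 uM; a higher number here means faster removal of the compound, a lower number slower removal. Compound 1 `CC(C)(O)CNCCCOc1ccc([C@H]2CC[C@]3(CC2)OOC2(O3)C3CC4CC(C3)CC2C4)cc1` gives 8 mL.min-1.g-1. Compound 2 `NCCS(=O)(=O)CCOc1ccc([C@H]2CC[C@]3(CC2)OOC2(O3)C3CC4CC(C3)CC2C4)cc1` gives 9 mL.min-1.g-1. Compound 3 `CC(C)(CN)Oc1ccc([C@H]2CC[C@]3(CC2)OOC2(O3)C3CC4CC(C3)CC2C4)cc1` gives < 7 mL.min-1.g-1, which is a limit of the assay and not a number. As far as these compounds go, it is the only one of the three measured compounds reported this way, so its true position remains open.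

The next compound is compound 4 `CC1(C)CC(O)(COc2ccc([C@H]3CC[C@]4(CC3)OOC3(O4)C4CC5CC(C4)CC3C5)cc2)CC(C)(C)N1`, and the change is (4-hydroxy-2,2,6,6-tetramethylpiperidin-4-yl)methyl in place of 1-(aminomethyl)-1-methylethyl on an oxygen on an aromatic ring. This brings in a six-membered non-aromatic ring with 1 hetero atom, on an oxygen on an aromatic ring.

The closest precedents are exchanges of the group on that oxygen: an at least 1.1-fold lower number from compound 1 to compound 3 (0.05 log units; that floor lies within the scatter) and an at least 1.2-fold lower number from compound 2 to compound 3 (0.10 log units; that floor lies within the scatter). Both are floors within the scatter. The exchange on the saturated chain carbon, a 1.1-fold higher number from compound 1 to compound 2 (0.05 log units; within the scatter), also lies within the scatter. None of the three compounds carries the entering ring, so these steps bear on it only indirectly.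

From the compounds shown here alone, with no measured step beyond the scatter, none beyond the scatter is expected in this assay here, and the direction stays open. The expected change is an at least 1.1-fold higher number from compound 3 to compound 4 (0.05 log units; that floor lies within the scatter). Compound 4 is estimated at 8 mL.min-1.g-1, with an expected range of 4 mL.min-1.g-1 to 18 mL.min-1.g-1.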

Compound 4, intrinsic clearance in microsomes: 14 mL.min-1.g-1
Compound 4: middle estimate off by 1.8-fold (0.24 log units), on the low side, and the stated range covers the measured number.
By their numbers in this assay, from the lowest: compounds 1, 2 and 4 (each within the scatter of the next). At a limit, below all of these: compound 3.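

Of the compounds shown, only compound 4 carries a six-membered non-aromatic ring with 1 hetero atom in the group on this oxygen, and in this assay that group stays within the scatter of both chain-bearing compounds, with a 1.6-fold higher number from compound 2 to compound 4 (0.19 log units; within the scatter) and a 1.8-fold higher number from compound 1 to compound 4 (0.24 log units; within the scatter). Exchanging 1-(aminomethyl)-1-methylethyl for (4-hydroxy-2,2,6,6-tetramethylpiperidin-4-yl)methyl at this position gives an at least 2.0-fold higher number from compound 3 to compound 4 (0.30 log units; that floor lies within the scatter). That step is only a floor because compound 3 is reported at a limit of the assay and not at a number: the limit of < 7 mL.min-1.g-1 in this assay, at which 1 of the 4 values shown sits.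

The compounds shown do not separate the contributions of the ring hydroxyl and the four ring methyl groups, which a 2,2,6,6-tetramethylpiperidine without the hydroxyl or a 4-hydroxypiperidine without the methyl groups, joined through the same methylene on this oxygen, would address. As far as these compounds go, the true distance between compound 3 and compound 4 also stays open, so it remains unknown whether this exchange produces a change beyond the scatter.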